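Quinolinyl for Fluorophenyl on a Shared Amidine Core

This account rests on a few compounds, and the source may have more. Where it says the series, first, only, none or still open, it means among the compounds named here.

This account concerns a small set of compounds built on a shared core that ends in an amidine, and how they fare in an ADME assay on HEK293 cells (Homo sapiens) for cytotoxicity, read by fluorescence and resazurin assay, with a stated time of 20 h; a lower number here means that less compound is tolerated, a higher number that more compound is tolerated. Among the compounds with values here, compound 1 `CC(C)CCc1sc(NC(=O)c2cc(NC(=O)c3cc(NC(=N)c4cccc(F)c4)cn3C)cn2C)nc1C(=O)NCCCN(C)C` is the only member with a reported number: in this assay compound 1 gives 18 ug/mL. Two relatives belong to the same set, compound 2 `CN(C)CCCNC(=O)c1cc(NC(=O)c2cc(NC(=O)c3cc(NC(=N)c4ccccc4)cn3C)cn2C)cn1C` and compound 3 `CC(C)CCn1cc(NC(=O)c2cc(NC(=O)c3cc(NC(=N)c4ccccc4)cn3C)cn2C)cc1C(=O)NCCCN(C)C`. In this assay compound 2 gives "not determined" (no result reported), and in the same assay compound 3 gives "not determined" (no result reported), so neither offers a number against which compound 1 could be set. Compound 1 therefore stands alone as the reference, with nothing above or below it.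

Compound 4 `CC(C)CCc1sc(NC(=O)c2cc(NC(=O)c3cc(NC(=N)c4cnc5ccccc5c4)cn3C)cn2C)nc1C(=O)NCCCN(C)C` differs from compound 1 in a single place: quinolin-3-yl in place of 3-fluorophenyl on a carbon with a double bond to nitrogen. Within the data shown here, no measured pair in the set shows what a change of this kind does in this assay, so the size of the step can only be estimated from compound 1 and the change itself. A modest step is expected, close to the edge of the usual scatter, tending toward somewhat less compound being tolerated. This estimate amounts to an expected step of a 1.5-fold lower number from compound 1 to compound 4 (0.18 log units; within the scatter). For compound 4 the expected value in this assay is 12 ug/mL, within a range from 5 ug/mL to 30 ug/mL.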

Compound 4, half-maximal cytotoxic concentration: 1.2 ug/mL
Compound 4: middle estimate off by 10-fold (1.00 log units), on the high side; the whole stated range lies above it.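

With compound 4, this position gains its first measured step: in this assay, quinolin-3-yl in place of 3-fluorophenyl on a carbon with a double bond to nitrogen gives a 15-fold lower number from compound 1 to compound 4 (1.18 log units; beyond the scatter). The rest of the structure is the same in both compounds, so this single exchange is enough to move the result beyond the usual scatter, toward less compound being tolerated, which compound 1 alone could not show. Nothing available bears on the reason for this step.

The change itself leaves open whether the step follows the second ring or the ring nitrogen, which are exchanged together here; a naphthalen-2-yl group, with carbon only in both rings, or a pyridin-3-yl group, with the ring nitrogen but no second ring, would separate the two. Within the data shown here, compound 2 and compound 3 carry a plain phenyl at this place but have no reported result, so no steps involving them can be read, and it stays open whether the same exchange would have a similar size on any other core.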